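From methoxycarbonyl to allyl on the shared core

A few compounds are considered here, and "the series" means these few. Any claim that something is new, unique, unknown or untested is made for them only; others in the source may bear on it.

Within the data shown here, the values below come from a functional assay with Rattus norvegicus as the target (on this read-out lower numbers stand for stronger inhibition and higher numbers for weaker inhibition), and cover the three compounds measured so far.

Compound 1 `COc1cccc2[nH]c(=O)c(=O)oc12` (7000 nM)
Compound 2 `COc1cc2[nH]c(=O)c(=O)oc2cc1OC` (30000 nM)
Compound 3 `COC(=O)c1cc(OC)c2oc(=O)c(=O)[nH]c2c1` (3400 nM)

Compound 3 at 3400 nM holds the lowest number of the three. Compound 4 `C=CCc1cc(OC)c2oc(=O)c(=O)[nH]c2c1` carries allyl in place of methoxycarbonyl on an aromatic carbon. Among the measured compounds shown here, the only measured step at this carbon is a 2.1-fold lower number from compound 1 to compound 3 (0.31 log units; beyond the scatter) when methoxycarbonyl replaces hydrogen. For the measured compounds named here, with that single step to go on, and no allyl compound measured, a small upward step in this assay is expected, no larger than that one. The estimate for compound 4 is 5000 nM (expected range 1800 nM to 14000 nM). The expected step is a 1.5-fold higher number from compound 3 to compound 4 (0.17 log units; within the scatter) by this estimate.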

Compound 4, half-maximal inhibitory concentration: 10000 nM
Compound 4: the middle estimate sits 2.0-fold (0.30 log units) below what was measured, and the stated range covers the measured number.
By their numbers in this assay, from the lowest: compound 3; then compounds 1 and 4 (each within the scatter of the next); then compound 2.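

In this assay the change from methoxycarbonyl to allyl gives a 2.9-fold higher number from compound 3 to compound 4 (0.47 log units; beyond the scatter) and so shows that the gain seen with methoxycarbonyl on this aromatic carbon does not extend to every group placed there. Allyl in place of hydrogen gives a 1.4-fold higher number from compound 1 to compound 4 (0.15 log units; within the scatter) and so cannot be told apart from hydrogen at this carbon, whereas methoxycarbonyl can. Nothing available explains why the two groups differ.

From the compounds shown here alone, whether a carboxylic acid or an amide on this carbon would follow methoxycarbonyl, and whether a propyl chain would follow allyl, remains open.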